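The source may report more compounds than this note shows. Statements on the series, on what has been measured and on what is new or still open speak of the compounds shown alone.

Measured so far in a functional assay on BJAB cells (Homo sapiens) for antiproliferative activity, with a stated time of 4 days; a lower number here means that less compound is needed, a higher number that more compound is needed for the effect:
compound 2 `Cc1ccccc1-c1c(C)nn(-c2nc(-c3ccc(Cl)c(Cl)c3)c(SC(C)C)s2)c1C(=O)O`: 5500 nM
compound 1 `COc1cccc(-c2c(C)nn(-c3nc(-c4ccc(Cl)c(Cl)c4)c(SC(C)C)s3)c2C(=O)O)c1`: 14000 nM
compound 3 `Cc1nn(-c2nc(-c3ccc(Cl)c(Cl)c3)c(SC(C)C)s2)c(C(=O)O)c1-c1cccnc1`: 12000 nM

Compound 2 stands lowest of the three, with a 2.5-fold lower number from compound 1 to compound 2 (0.41 log units; beyond the scatter) and a 2.2-fold higher number from compound 2 to compound 3 (0.34 log units; beyond the scatter) both beyond the scatter, so the 2-methylphenyl group gives the best number seen. Compound 4 `Cc1nn(-c2nc(-c3ccc(Cl)c(Cl)c3)c(SC(C)C)s2)c(C(=O)O)c1-c1ccc(Cl)cc1` differs from compound 2 in that (4-chlorophenyl in place of 2-methylphenyl on an aromatic carbon). Among the compounds with values here, no measured step swaps one substituted phenyl for another of this kind, so the two steps that leave 2-methylphenyl are the only guide, and each went up modestly. A modest rise is therefore expected, a 1.5-fold higher number from compound 2 to compound 4 (0.16 log units; within the scatter), with wide uncertainty. Compound 4 is estimated at 8000 nM, within 3000 nM to 22000 nM.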

Compound 4, half-maximal effective concentration: 2500 nM
Compound 4: the middle estimate sits 3.2-fold (0.51 log units) above what was measured; the whole stated range lies above it.
By their numbers in this assay, from the lowest: compound 4; then compound 2; then compounds 3 and 1 (each within the scatter of the next).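

Within the data shown here, at this aromatic carbon, 4-chlorophenyl is the first group to fall below 2-methylphenyl in this assay (a 2.2-fold lower number from compound 2 to compound 4 (0.34 log units; beyond the scatter)). The gaps to the other two groups are wider (a 4.8-fold lower number from compound 3 to compound 4 (0.68 log units; beyond the scatter); a 5.6-fold lower number from compound 1 to compound 4 (0.75 log units; beyond the scatter)), so compound 4 stands lowest of the four, with every step to it beyond the scatter. Nothing available explains this gain.

Still open, from the compounds shown here alone, is whether the chlorine itself matters, since an amine or a fluorine in its place on the phenyl ring would test this.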